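The source may report more compounds than this note shows. Statements on the series, on what has been measured and on what is new or still open speak of the compounds shown alone.

Compounds measured so far in an ADME assay on microsomes from liver (Homo sapiens) for metabolic stability, read by LC-MS, tested at 1 uM; on this read-out higher numbers stand for fast clearance and lower numbers for slow clearance:

compound 1 `O=S(=O)(c1ccc([C@H]2CC[C@]3(CC2)OOC2(O3)C3CC4CC(C3)CC2C4)cc1)N1CCNCC1` — 16 mL.min-1.g-1
compound 2 `NCCOCCOc1ccc([C@H]2CC[C@]3(CC2)OOC2(O3)C3CC4CC(C3)CC2C4)cc1` — < 7 mL.min-1.g-1
compound 3 `c1cc([C@H]2CC[C@]3(CC2)OOC2(O3)C3CC4CC(C3)CC2C4)ccc1OCCCNC1CCOCC1` — 10 mL.min-1.g-1

Compound 1 has the highest of the two numbers shown; compound 3 is nearest, and the gap between them, a 1.6-fold lower number from compound 1 to compound 3 (0.20 log units; within the scatter), lies within the scatter. The value of compound 2 is a limit of this assay, not a number, the one described by the limit of < 7 mL.min-1.g-1 in this assay, at which 1 of the 3 values shown sits.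

Compound 4 `CC(C)(N)CCOc1ccc([C@H]2CC[C@]3(CC2)OOC2(O3)C3CC4CC(C3)CC2C4)cc1` has not yet been measured in this assay. It differs from compound 1 as follows: 3-amino-3-methylbutoxy in place of (piperazin-1-yl)sulfonyl on an aromatic carbon. Among the compounds with values here, two measured steps bear on this change, since both also replace the (piperazin-1-yl)sulfonyl of compound 1 with an amine-bearing alkoxy chain on the same aromatic carbon. The first, an at least 2.2-fold lower number from compound 1 to compound 2 (0.35 log units; beyond the scatter), is at least modest and beyond the scatter. The second, a 1.6-fold lower number from compound 1 to compound 3 (0.20 log units; within the scatter), stays within the scatter. The step between the two chains, an at least 1.4-fold higher number from compound 2 to compound 3 (0.15 log units; that floor lies within the scatter), has a floor within the scatter. The 3-amino-3-methylbutoxy group is a plain chain without a ring, closer in kind to the chain in compound 2 than to the ring-bearing chain in compound 3.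

A lower number than compound 1 is therefore expected for compound 4, of about the size a 2.0-fold lower number from compound 1 to compound 4 (0.30 log units; within the scatter), with a fair chance that only a limit is reported. The estimate for compound 4 in this assay is 8 mL.min-1.g-1, within 4 mL.min-1.g-1 to 14 mL.min-1.g-1.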

Compound 4, intrinsic clearance in microsomes: < 7 mL.min-1.g-1
Compound 4: only a limit was reported; the forecaster's own chance of this, stated with the estimate: 35%; middle value at least 1.1-fold (0.05 log units) away from the limit.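

In this assay, 3-amino-3-methylbutoxy in place of (piperazin-1-yl)sulfonyl on the aromatic carbon para to a large group gives an at least 2.2-fold lower number from compound 1 to compound 4 (0.35 log units; beyond the scatter), so a second amine-bearing alkoxy chain without a ring now gives a step beyond the scatter. Set against the chain carrying the oxan-4-yl group, the change gives an at least 1.4-fold lower number from compound 3 to compound 4 (0.15 log units; that floor lies within the scatter), and that floor does not by itself separate the two chains. The step between compound 2 and compound 4 cannot be read, as compound 2 and compound 4 both end at the same limit of the assay: the limit of < 7 mL.min-1.g-1 in this assay, at which 2 of the 4 values shown sit.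

From the compounds shown here alone, how far compound 2 and compound 4 lie past that limit stays open, and with it any ranking of the two plain chains, including whether the two methyl groups of the 3-amino-3-methylbutoxy chain count for anything in this read-out. Also open, going by these compounds, is whether the amine at the chain end is needed at all, a question that a 3-hydroxy-3-methylbutoxy chain or a carboxylic acid at the same chain end would address on the shared core.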